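Swapping 3-chlorophenyl for benzyl on compound 3

The compounds below may be only part of what the source reports. "The series", "measured", "known", "first", "only" and "open" are said of these compounds alone.

Measured so far in a functional assay on T98G cells (Homo sapiens) for inhibition, read by MTT assay, with a stated time of 72 h (on this read-out higher numbers stand for weaker inhibition and lower numbers for stronger inhibition), are three compounds
compound 1 `CC1(C)CC(NC(=O)Nc2ccccc2Cl)c2cc(F)ccc2O1` gives 27000 nM
compound 2 `CC1(C)CC(NC(=O)NCc2ccccc2)c2cc(Br)ccc2O1` gives 38000 nM
compound 3 `CC1(C)CC(NC(=O)Nc2cccc(Cl)c2)c2cc(F)ccc2O1` gives 45000 nM

In this assay compound 3 stands at 45000 nM and lies within the usual scatter of compound 1 and compound 2. Compound 4 `CC1(C)CC(NC(=O)NCc2ccccc2)c2cc(F)ccc2O1` has not been measured. It carries benzyl in place of 3-chlorophenyl on an amide-type nitrogen compared with compound 3. Among the compounds with values here, the only measured step at that place is a 1.7-fold higher number from compound 1 to compound 3 (0.22 log units; within the scatter) with 3-chlorophenyl in place of 2-chlorophenyl, and it stays within the scatter. Within the data shown here, no measured step brings in benzyl on this same core. Compound 2 also carries benzyl there, on a core that is not identical, and gives 38000 nM in this read-out. No step beyond the scatter is therefore expected, in either direction. The expected size is a 1.1-fold lower number from compound 3 to compound 4 (0.05 log units; within the scatter) and so within the scatter. Compound 4 is estimated at 40000 nM with 20000 nM to 80000 nM as its expected range.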

Compound 4, half-maximal inhibitory concentration: 49000 nM
Compound 4: the middle estimate sits 1.2-fold (0.09 log units) below what was measured; the range from low to high includes it.
By their numbers in this assay, from the lowest: compounds 1, 2, 3 and 4 (each within the scatter of the next).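

In this assay, benzyl on the amide-type nitrogen can now be read on the same core as the chlorophenyl groups: replacing 3-chlorophenyl gives a 1.1-fold higher number from compound 3 to compound 4 (0.04 log units; within the scatter) and replacing 2-chlorophenyl gives a 1.8-fold higher number from compound 1 to compound 4 (0.26 log units; within the scatter). Fluoro in place of bromo on an aromatic carbon, with benzyl kept, gives a 1.3-fold higher number from compound 2 to compound 4 (0.11 log units; within the scatter). Neither place has yet produced a change that stands out from the scatter.

No supporting data offer an explanation for these results. Going by these compounds, whether an amine, a carboxylic acid or a longer chain on that nitrogen would move the number beyond the scatter remains open.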